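A second 4-hydroxybenzyl group on the shared core

This account rests on a few compounds, and the source may have more. Where it says the series, first, only, none or still open, it means among the compounds named here.

Compound 1 `COc1ccc2c(c1)cc(-c1cc(OC)c(OC)c(OC)c1)n2Cc1ccccc1` sets the shared core, and a functional assay on MDA-MB-231 cells (Homo sapiens) for cytotoxicity, read by MTT assay, with a stated time of 24 h (on this read-out lower numbers stand for stronger inhibition and higher numbers for weaker inhibition), is the only read-out available. Compound 1 returns only a limit, > 30000 nM. Compound 2 `COc1ccc2c(c1)cc(-c1cc(OC)c(OC)c(OC)c1)n2Cc1ccc(OCc2ccccc2)cc1`, which adds a benzyloxy group, also returns only a limit, > 30000 nM. Within the data shown here, compound 3 `COc1ccc2c(c1)cc(-c1cc(OC)c(OC)c(OC)c1)n2Cc1ccc(O)cc1`, which carries a hydroxy group instead, gives 17300 nM, the only true number in the set. The rest of the data sit at the limit of > 30000 nM in this assay, at which 2 of the 3 values shown sit.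

Compound 4 `COc1ccc2c(c1)c(Cc1ccc(O)cc1)c(-c1cc(OC)c(OC)c(OC)c1)n2Cc1ccc(O)cc1` builds on compound 3: 4-hydroxybenzyl in place of hydrogen on an aromatic carbon. Among the measured compounds shown here, no measured step changes this place on the core, so the evidence is indirect. The step to the hydroxy compound from the unsubstituted one is an at least 1.7-fold lower number from compound 1 to compound 3 (0.23 log units; that floor lies within the scatter). The step from the benzyloxy compound is an at least 1.7-fold lower number from compound 2 to compound 3 (0.23 log units; that floor lies within the scatter). Both are floors only, and the remaining step is a step that the two limits leave unreadable from compound 1 to compound 2. Nothing here supports a step beyond the scatter in this assay, in either direction, so none is expected, and a further report of a limit remains possible. The expected change is a 1.2-fold lower number from compound 3 to compound 4 (0.06 log units; within the scatter). For compound 4 the estimated value is 15000 nM, with an expected range of 5000 nM to 30000 nM.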

Compound 4, half-maximal inhibitory concentration: > 30000 nM
Compound 4: no number, only a limit (the forecaster's own chance of this, stated with the estimate: 30%); middle value at least 2.0-fold (0.30 log units) from the limit.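

In this assay, this is the first change shown at this place on the shared core, the aromatic carbon next to the ring atom that bears a 3,4,5-trimethoxyphenyl group, and 4-hydroxybenzyl there gives an at least 1.7-fold higher number from compound 3 to compound 4 (0.23 log units; that floor lies within the scatter). The floor of this step fixes no size and does not show a change beyond the scatter, so this place cannot be called intolerant of substitution; what the result does show is that this one group, on top of the hydroxy group of compound 3, does not bring a number within the range of the assay. Compound 4 thus returns only a limit, and compound 3 remains the only compound in the set with a true number: the limit of > 30000 nM in this assay, at which 3 of the 4 values shown sit.

On these data alone, whether a methyl group, an amine or a carboxylic acid at this place would give a readable number stays open, as does whether a plain benzyl group would behave like 4-hydroxybenzyl there. Also open, as far as these compounds go, is whether the hydroxy group on the new benzyl ring matters at all, and how far the true value of compound 4 lies from that of compound 3.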